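Carboxylic Acid to (Methylsulfonyl)carbamoyl: Expecting Compound 3

A few compounds are considered here, and "the series" means these few. Any claim that something is new, unique, unknown or untested is made for them only; others in the source may bear on it.

Measured so far:
- compound 1, `O=C(O)CCCOc1ccc(Cl)cc1C1CCCCC1`: 1990 nM
- compound 2, `O=C(O)CCOc1ccc(Cl)cc1C1CCCCC1`: 799 nM

In an assay on CHO cells for displacement of a labelled ligand from prostaglandin D2 receptor 2 (Homo sapiens) (on this read-out higher numbers stand for weaker inhibition and lower numbers for stronger inhibition), compound 2 gives the lowest of the two numbers, and its nearest neighbour is compound 1, separated by a 2.5-fold lower number from compound 1 to compound 2 (0.40 log units; beyond the scatter). That single step, carboxy in place of carboxymethyl on a saturated chain carbon, shortened the chain by one link and gave a modest gain.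

Compound 3, `CS(=O)(=O)NC(=O)COc1ccc(Cl)cc1C1CCCCC1`, has not been measured. It differs from compound 2 by (methylsulfonyl)carbamoyl in place of carboxymethyl on a saturated chain carbon bound to an oxygen on an aromatic ring. Among the measured compounds shown here, no measured step covers this exchange; the only step known, from compound 1 to compound 2, concerns chain length alone. The change for compound 3 again removes one chain link, while the end group itself is new. The expected outcome is therefore a change of about a 1.6-fold lower number from compound 2 to compound 3 (0.20 log units; within the scatter) in this assay, with wide uncertainty. Compound 3 is estimated at 500 nM, in the range 150 nM to 2000 nM.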

Compound 3, inhibition constant: > 10000 nM
Compound 3: a limit, no number; the forecaster's own chance of this, stated with the estimate: 5%; middle value at least 20-fold (1.30 log units) from the limit.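

In this assay compound 3 gives > 10000 nM, which is a limit of the assay and not a number: the limit of > 10000 nM in this assay, at which 1 of the 3 values shown sits.

Even read as a limit, the result shows that this position does not accept every change. Exchanging carboxymethyl for (methylsulfonyl)carbamoyl on this saturated chain carbon gives an at least 12-fold higher number from compound 2 to compound 3 (1.09 log units; beyond the scatter), and the comparison with the longer acid points the same way, with an at least 5.0-fold higher number from compound 1 to compound 3 (0.70 log units; beyond the scatter). Shortening the chain had brought a modest gain, whereas this new end group, on a chain also one link shorter, brings a large loss.

The compounds shown cannot separate the effect of the new end group from that of the shorter chain, as both change together in compound 3. A carboxylic acid, a tetrazole or a simple amide on that same chain carbon would help separate them.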